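Adding a Methyl to the Side Chain of Compound 2

The source may report more compounds than this note shows. Statements on the series, on what has been measured and on what is new or still open speak of the compounds shown alone.

Compound 1 `OCc1cn(CCNc2nonc2/C(=N/O)Nc2ccc(F)c(Br)c2)nn1`: 794 nM
Compound 2 `CC(OCCO)c1cn(CCNc2nonc2/C(=N/O)Nc2ccc(F)c(Br)c2)nn1`: 930 nM

Both compounds were tested in an assay on isolated protein for inhibition of Indoleamine 2,3-dioxygenase 2 (Homo sapiens); a lower number here means a stronger inhibitor, a higher number a weaker inhibitor. Among the measured compounds shown here, compound 2 has the higher of the two numbers, yet the single step connecting them, a 1.2-fold higher number from compound 1 to compound 2 (0.07 log units; within the scatter), falls within the scatter, so the two compounds cannot be told apart on these values.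

Compound 3 `CC(C)(OCCO)c1cn(CCNc2nonc2/C(=N/O)Nc2ccc(F)c(Br)c2)nn1` is the next step in the same series. It differs from compound 2 by methyl in place of hydrogen on a saturated chain carbon bound to an aromatic carbon, an oxygen on a saturated carbon and a saturated chain carbon, so the side chain on the shared core grows from 1-(2-hydroxyethoxy)ethyl to 1-(2-hydroxyethoxy)-1-methylethyl.

For the measured compounds named here, only one measured step bears on this change: a 1.2-fold higher number from compound 1 to compound 2 (0.07 log units; within the scatter). That step replaced hydroxymethyl at the same position with a much larger group and still left the number within the scatter. A single extra methyl on that chain is a smaller alteration than the one already seen. The expected step to compound 3 is therefore none beyond the scatter, a 1.1-fold higher number from compound 2 to compound 3 (0.03 log units; within the scatter). For compound 3 in this assay the estimate is 1000 nM, expected to lie between 400 nM and 2500 nM.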

Compound 3, half-maximal inhibitory concentration: 1170 nM
Estimate against measurement, compound 3: 1.2-fold (0.07 log units) below; measured number inside the range.
By their numbers in this assay, from the lowest: compounds 1, 2 and 3 (each within the scatter of the next).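

In this assay the added methyl gives a 1.3-fold higher number from compound 2 to compound 3 (0.10 log units; within the scatter) and so leaves compound 3 indistinguishable from compound 2: a saturated chain carbon that already carries a methyl can take a second one, becoming 1-(2-hydroxyethoxy)-1-methylethyl, with no change these values can resolve. Read over the whole distance, the replacement of hydroxymethyl gives a 1.5-fold higher number from compound 1 to compound 3 (0.17 log units; within the scatter) and also stays within the scatter, so none of the three side chains can yet be separated from another at this position, even though they differ visibly in size on paper. Nothing available accounts for this flat result, and the numbers alone cannot say why the position responds so little.

On these data alone, it remains open whether a group of a different kind at this position, such as an amine or a carboxylic acid, would move the number beyond the scatter. A longer chain in place of 1-(2-hydroxyethoxy)-1-methylethyl is just as open, so the flat result holds only for these three side chains on the shared core.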